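The compounds below may be only part of what the source reports. "The series", "measured", "known", "first", "only" and "open" are said of these compounds alone.

Measured so far:
compound 1 `Cn1cncc1C(O)(c1ccc([N+](=O)[O-])cc1)c1cc2cc([N+](=O)[O-])cc(-c3ccccc3)c2o1` gives 547 nM
compound 2 `COc1cccc(-c2cc([N+](=O)[O-])cc3cc(C(O)(c4ccc(C#N)cc4)c4cncn4C)oc23)c1` gives 38.8 nM

In a functional assay on QG-56 cells (Homo sapiens) for antiproliferative activity (a lower number here means a stronger inhibitor, a higher number a weaker inhibitor), compound 2 at 38.8 nM holds the lower of the two numbers, and compound 1 at 547 nM lies higher, beyond the scatter. Compound 3 `Cn1cncc1C(O)(c1ccc(C#N)cc1)c1cc2cc([N+](=O)[O-])cc(-c3ccccc3F)c2o1` has 2-fluorophenyl in place of 3-methoxyphenyl on an aromatic carbon when set against compound 2. Going by the values given here, no measured pair differs in one place only, so the data do not size this change. No shift beyond the scatter is expected, with a slight lean toward a higher number. The expected change is a 1.5-fold higher number from compound 2 to compound 3 (0.19 log units; within the scatter) in this estimate. For compound 3 the estimated value is 60 nM with 20 nM to 180 nM as the expected range.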

Compound 3, half-maximal inhibitory concentration: 89.5 nM
Estimate against measurement, compound 3: 1.5-fold (0.17 log units) below; measured number inside the range.
By their numbers in this assay, from the lowest: compound 2; then compound 3; then compound 1.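

In this assay, going by these compounds alone, 2-fluorophenyl in place of 3-methoxyphenyl on this aromatic carbon gives a 2.3-fold higher number from compound 2 to compound 3 (0.36 log units; beyond the scatter) as the first sized change at this position. The step is modest but beyond the scatter, so the number at this position responds to the aryl group it carries. No measured evidence here accounts for the step.

The step changes both the substituent and its place on the phenyl ring, and the two effects remain unseparated. From the compounds shown here alone, how an amine or a carboxylic acid on that phenyl ring would register also remains open.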